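Aryl group in place of hydroxypropyl chain

The source may report more compounds than this note shows. Statements on the series, on what has been measured and on what is new or still open speak of the compounds shown alone.

Going by the values given here, compound 2 `COc1nc2ccc(Br)cc2cc1C(c1ccccc1)n1cc(CCCO)nn1` stands highest of the two numbers so far in an ADME assay on PC-3 cells (Homo sapiens) for cytotoxicity, read by sulforhodamine B assay, with a stated time of 48 h, tested at 10 uM (on this read-out higher numbers stand for more inhibition at the one concentration tested (going by the name of the read-out) and lower numbers for less inhibition), where compound 2 gives 14.7%. Its nearest neighbour is compound 1 `CCCCCc1cn(C(c2ccccc2)c2cc3cc(Br)ccc3nc2OC)nn1`, which in this assay gives 11.4%, the two values sitting within the scatter of each other. Among the compounds with values here, the only measured step, a number 3.3 percentage points higher from compound 1 to compound 2 (within the scatter), is a change on the chain and lies within the scatter. Compound 3 `COc1nc2ccc(Br)cc2cc1C(c1ccccc1)n1cc(-c2ccc(OC(F)(F)F)cc2)nn1` differs from compound 2 by 4-(trifluoromethoxy)phenyl in place of 3-hydroxypropyl on an aromatic carbon. Within the data shown here, no measured step swaps a chain for an aromatic ring at this site, so the step from compound 1 to compound 2 bears on it only loosely, and both measured numbers are low and close. For compound 3 the expected value in this assay is 22%, with a range of 5% to 45%. This estimate corresponds to an expected step of a number 7.3 percentage points higher from compound 2 to compound 3 (within the scatter), which may or may not exceed the scatter.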

Compound 3, a percentage reported as inhibition, at one concentration (the size of the read-out at that concentration, not a potency): 21.6%
The estimate for compound 3 lay 0.4 percentage points above the measured number; the measured number falls inside the stated range.
By their numbers in this assay, from the lowest: compounds 1, 2 and 3 (each within the scatter of the next, the first and the last beyond it).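

In this assay, the position on the aromatic carbon of the five-membered ring accepts an aromatic ring as well as a chain: the step, a number 6.9 percentage points higher from compound 2 to compound 3 (within the scatter), does not separate 4-(trifluoromethoxy)phenyl from 3-hydroxypropyl. Going by these compounds alone, measured against pentyl, the same aryl group gives the only step that clears the scatter, a number 10.2 percentage points higher from compound 1 to compound 3 (beyond the scatter), while all three numbers stay low. Nothing measured here accounts for either step.

From the compounds shown here alone, whether the step from pentyl depends on the aromatic ring itself or on its trifluoromethoxy group stays open, and an unsubstituted phenyl at this position would separate the two. Also open, going by these compounds, is how an amine or a carboxylic acid at the end of the chain would read in this assay.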